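Phenyl for bromo: expectation for compound 3

The compounds below may be only part of what the source reports. "The series", "measured", "known", "first", "only" and "open" are said of these compounds alone.

Measured so far:
compound 1 `COC1(Cc2cccc(Cl)c2)CCN(c2ccc(C(=O)NS(=O)(=O)c3ccc(N[C@H](CCN(C)C)CSc4ccccc4)c([N+](=O)[O-])c3)cc2)CC1`: 300 nM
compound 2 `COC1(Cc2ccccc2Br)CCN(c2ccc(C(=O)NS(=O)(=O)c3ccc(N[C@H](CCN(C)C)CSc4ccccc4)c([N+](=O)[O-])c3)cc2)CC1`: 200 nM

In a functional assay (FL5.12 cells, Mus musculus) with Apoptosis regulator Bcl-2 (Homo sapiens) as the target (a higher number here means that more compound is needed for the effect, a lower number that less compound is needed), compound 1 gives 300 nM and compound 2 gives 200 nM. Compound 2 holds the lower of the two numbers, with compound 1 as its nearest neighbour, but the step of a 1.5-fold lower number from compound 1 to compound 2 (0.18 log units; within the scatter) is within the scatter, so the two compounds cannot be told apart on these data.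

Compound 3 `COC1(Cc2ccccc2-c2ccccc2)CCN(c2ccc(C(=O)NS(=O)(=O)c3ccc(N[C@H](CCN(C)C)CSc4ccccc4)c([N+](=O)[O-])c3)cc2)CC1` differs from compound 2 by phenyl in place of bromo on an aromatic carbon. For the measured compounds named here, the single measured step, a 1.5-fold lower number from compound 1 to compound 2 (0.18 log units; within the scatter), exchanges one halogen-bearing phenyl for another and is within the scatter; it does not cover the exchange of a halogen for a phenyl ring. Going by the values given here, no measured pair therefore bears directly on the present change, and the series gives no direction for it.

With nothing to support a shift either way, compound 3 is expected to stay near compound 2, the step of a 1.5-fold higher number from compound 2 to compound 3 (0.18 log units; within the scatter) being the estimate, with a wide range to reflect the untested change. The estimate for compound 3 in this assay is 300 nM, between 80 nM and 1200 nM.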

Compound 3, half-maximal effective concentration: 20 nM
For compound 3 the middle estimate is 15-fold (1.18 log units) above the measured one; measured number outside the range, below it.
By their numbers in this assay, from the lowest: compound 3; then compounds 2 and 1 (each within the scatter of the next).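

In this assay, the aromatic carbon that carries bromo in compound 2 turns out to respond strongly to the group placed on it: phenyl in place of bromo gives a 10-fold lower number from compound 2 to compound 3 (1.00 log units; beyond the scatter), whereas the exchange between the two halogen-bearing phenyl groups gave only a 1.5-fold lower number from compound 1 to compound 2 (0.18 log units; within the scatter) and stayed within the scatter. The 2-phenylphenyl group also separates clearly from the 3-chlorophenyl group, with a 15-fold lower number from compound 1 to compound 3 (1.18 log units; beyond the scatter), so compound 3 stands apart from two compounds that cannot themselves be told apart. Nothing at hand accounts for this drop in the number, so the result remains an observation on these three compounds only.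

The compounds shown hold only bromo and phenyl on this aromatic carbon, so it stays open whether the aromatic ring itself matters or any group of similar size would serve, and a cyclohexyl or a pyridyl ring there would bear on that. Also open, going by these compounds, is whether a chloro, a methoxy or an amine on the new phenyl ring would move the number further, and whether the step carries over to other changes on the shared core.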